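A few compounds are considered here, and "the series" means these few. Any claim that something is new, unique, unknown or untested is made for them only; others in the source may bear on it.

Compound 1 `Nc1nc2c(c(-c3ccco3)cn2[C@@H]2O[C@H](CO)[C@@H](O)[C@H]2O)c(=O)[nH]1`: > 20000 nM (a limit, not a number)
Compound 2 `Nc1nc2c(c(-c3ccoc3)cn2[C@@H]2O[C@H](CO)[C@@H](O)[C@H]2O)c(=O)[nH]1`: 17600 nM
Compound 3 `Nc1nc2c(c(-c3cccs3)cn2[C@@H]2O[C@H](CO)[C@@H](O)[C@H]2O)c(=O)[nH]1`: 19800 nM

These three compounds share one core and were tested in a functional assay on HCT-116 cells (Homo sapiens), read by MTT assay, with a stated time of 72 h; a higher number here means a weaker inhibitor, a lower number a stronger inhibitor. They differ only in the aromatic ring on that core. The value of compound 1 is a limit of the assay, the one recorded as the limit of > 20000 nM in this assay, at which 1 of the 3 values shown sits. Compound 3 has a measured neighbour only in compound 2, and the two lie within the scatter of each other: a 1.1-fold higher number from compound 2 to compound 3 (0.05 log units; within the scatter).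

Compound 4 `Nc1nc2c(c(-c3ccccc3)cn2[C@@H]2O[C@H](CO)[C@@H](O)[C@H]2O)c(=O)[nH]1` has phenyl in place of thiophen-2-yl on an aromatic carbon. Among the measured compounds shown here, no measured step brings in a six-membered ring, so the closest guide is the exchanges among five-membered rings. One of these, an at least 1.1-fold lower number from compound 1 to compound 2 (0.05 log units; that floor lies within the scatter), has a floor within the scatter. Another, a number no higher from compound 1 to compound 3 (the limit leaves the size open), leaves its size open. The only step with a readable size is the one from furan-3-yl to thiophen-2-yl given above, and it is within the scatter. No step beyond the scatter is therefore expected in this assay, and no direction can be favoured. The expected change is a 1.0-fold higher number from compound 3 to compound 4 (0.00 log units; within the scatter). Compound 4 may well be reported only as a limit. For compound 4 the estimated value is 20000 nM, with an expected range from 10000 nM to 40000 nM.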

Compound 4, half-maximal inhibitory concentration: > 20000 nM
Compound 4 was reported as a limit (the forecaster's own chance of this, stated with the estimate: 50%); the middle value sits exactly at the limit.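

In this assay, among the compounds shown here, compound 4 is recorded only as a limit, the same limit as compound 1, giving a number no lower from compound 3 to compound 4 (the limit leaves the size open) and this is the first sign that a six-membered aromatic ring of carbon only ends up there too: the limit of > 20000 nM in this assay, at which 2 of the 4 values shown sit. For the compounds shown here, replacing a five-membered aromatic ring with phenyl on this aromatic carbon therefore brought no readable gain; the one step with a readable floor is an at least 1.1-fold higher number from compound 2 to compound 4 (0.05 log units; that floor lies within the scatter), while the step from compound 1 to compound 4 cannot be read. Across compounds 1 to 4, neither the size of the ring nor the presence or identity of its hetero atom separates any compound from the others in this assay, so this position now shows the same flat picture for four different aromatic rings.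

All four compounds carry an unsubstituted aromatic ring at this place, so the set leaves open whether any other kind of group here could bring the number clearly down. An amine, a short chain such as ethyl, or a phenyl ring bearing a hydroxyl or a methoxy group would test this, and the compounds shown say nothing about how such groups behave.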